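This account rests on a few compounds, and the source may have more. Where it says the series, first, only, none or still open, it means among the compounds named here.

Working notes on the series. Among the measured compounds shown here, compound 1 `CN(C(=O)c1ccc(Cl)cc1)c1ccc2[nH]c(-c3n[nH]c4ccccc34)cc2n1` stands at the lowest of the two numbers measured so far: in a functional assay on HL-60 cells (Homo sapiens) for antiproliferative activity, read by MTT assay, with a stated time of 72 h (on this read-out higher numbers stand for weaker inhibition and lower numbers for stronger inhibition), compound 1 gives 450 nM. For the measured compounds named here, compound 2 `CN(C(=O)c1ccccc1)c1ccc2[nH]c(-c3n[nH]c4cc(C#N)ccc34)cc2n1` differs from compound 1 in more than one place, so no single step connects the two; in this assay compound 2 gives 6430 nM, a number that lies beyond the scatter from that of compound 1, but nothing more can be read from this pair. Compound 3 `CN(c1ccc2[nH]c(-c3n[nH]c4ccccc34)cc2n1)S(=O)(=O)c1ccc(Br)cc1` is not yet measured. It differs from compound 1 in one place only: (4-bromophenyl)sulfonyl in place of (4-chlorophenyl)carbonyl on a nitrogen on an aromatic ring. Going by the values given here, no step between measured compounds is available to calibrate this change, as the only measured pair differs in two places at once. The expected step is a 2.0-fold higher number from compound 1 to compound 3 (0.30 log units; within the scatter), a modest move toward weaker inhibition, though a result within the scatter cannot be ruled out. For compound 3 the estimated value in this assay is 900 nM, with a range from 250 nM to 3500 nM.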

Compound 3, half-maximal inhibitory concentration: 6240 nM
The estimate for compound 3 lay 6.9-fold (0.84 log units) below the measured number; the measured number lies above the stated range.
By their numbers in this assay, from the lowest: compound 1; then compounds 3 and 2 (each within the scatter of the next).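

The position on the nitrogen on an aromatic ring, whose other neighbours are an aromatic carbon and a saturated chain carbon, is now shown to matter in this assay: (4-bromophenyl)sulfonyl in place of (4-chlorophenyl)carbonyl gives a 14-fold higher number from compound 1 to compound 3 (1.14 log units; beyond the scatter), a large move toward weaker inhibition. This is the first single-place step in the series, and it shows that the two groups are not interchangeable here even though both carry a six-membered aromatic ring of carbon only, so the earlier pair, which differed in more than one place, could not have shown this. No measured evidence bears on why the change costs so much inhibition.

The step changes the carbonyl to a sulfonyl and the chlorine to a bromine at once, so the compounds shown cannot assign the shift to either part, and (4-bromophenyl)carbonyl or (4-chlorophenyl)sulfonyl at this position would separate the two. Also open, on these data alone, is how this position responds to groups of another kind, such as an acetyl group, a simple benzyl group or a ring bearing a carboxylic acid.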